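This account rests on a few compounds, and the source may have more. Where it says the series, first, only, none or still open, it means among the compounds named here.

Compound 1, `CCOC(=O)c1cccc(-c2ccc(OCC)cc2)c1`, gives 87% in an assay on COS-7 cells for inhibition of patatin-like phospholipase domain-containing protein 2 (Mus musculus), tested at 200 uM; a lower number here means less inhibition, a higher number more inhibition at the concentration tested (going by the name of the read-out).
Compound 2, `CCOc1ccc(-c2cccc(C(=O)O)c2)cc1`, gives 23%.
Compound 3, `CCNC(=O)c1cccc(-c2ccc(OCC)cc2)c1`, gives 62%.

All three share one core and differ only in the group carried on one of its aromatic carbons. Compound 3 stands second highest of the three: it sits a number 25 percentage points lower from compound 1 to compound 3 (beyond the scatter), and a number 39 percentage points higher from compound 2 to compound 3 (beyond the scatter). The largest movement seen so far is a number 64 percentage points lower from compound 1 to compound 2 (beyond the scatter), so the group at this position clearly matters.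

Compound 4, `CCOc1ccc(-c2cccc(NC(C)=O)c2)cc1`, has not yet been measured in this assay. It differs from compound 3 in one place: acetamido in place of ethylcarbamoyl on an aromatic carbon. Going by the values given here, no measured step swaps one amide for another, so the existing steps only show that changing this group can move the read-out a great deal, as between compound 1 and compound 2, or moderately, as between compound 1 and compound 3. Since the leaving and entering groups both keep one hydrogen-bond donor and one acceptor, a modest downward step, a number 12 percentage points lower from compound 3 to compound 4 (beyond the scatter), is expected, and compound 4 is estimated at 50%, between 25% and 75%.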

Compound 4, a percentage reported as inhibition, at one concentration (the size of the read-out at that concentration, not a potency): 52%
Beside the measured number, compound 4's estimate is 2 percentage points below it; measured number inside the range.
By their numbers in this assay, from the lowest: compound 2; then compounds 4 and 3 (each within the scatter of the next); then compound 1.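

In this assay, acetamido in place of ethylcarbamoyl gives a number 10 percentage points lower from compound 3 to compound 4 (within the scatter), so at this position an amide joined to the ring through its nitrogen reads like one joined through its carbonyl carbon. Acetamido also stays apart from the other two groups, with a number 29 percentage points higher from compound 2 to compound 4 (beyond the scatter) and a number 35 percentage points lower from compound 1 to compound 4 (beyond the scatter), which places both amides in the middle, clear of carboxy and ethoxycarbonyl. No measurement shown explains why these groups differ.

Still open, from the compounds shown here alone, is whether the amide hydrogen matters, which a dimethylcarbamoyl group on the same aromatic carbon would test. A plain amine there, or a longer chain on the acetamido carbonyl, would show whether the read-out stays with the amides or moves toward either ester or acid.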